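A methyl gives way to fluoro

The compounds below may be only part of what the source reports. "The series", "measured", "known", "first", "only" and "open" are said of these compounds alone.

compound 1 `Cc1ccc2nc(-c3ccccc3N(C)C)[nH]c(=O)c2c1` | 26700 nM
compound 2 `Cc1cccc(-c2nc3cc(C)ccc3c(=O)[nH]2)c1` | > 50000 nM
compound 3 `CCN(CC)c1ccc2nc(-c3ccccc3C(F)(F)F)[nH]c(=O)c2c1` | 2550 nM

All three compounds were tested in a functional assay on T47D cells (Homo sapiens) for cytotoxicity, read by MTT assay, with a stated time of 2 days; a lower number here means a stronger inhibitor, a higher number a weaker inhibitor. Compound 1 and compound 3 returned numbers, and neither of them differs from compound 2 in one place alone.

Compound 2 gives > 50000 nM in this assay, which is a limit and not a number. The series therefore shows (the limit of > 50000 nM in this assay, at which 1 of the 3 values shown sits). Among the compounds with values here, compound 2 has no exact position on the scale, and no measured step shows what a single change does.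

The next compound, compound 4 `Cc1ccc2c(=O)[nH]c(-c3cccc(F)c3)nc2c1`, has not yet been measured. It departs from compound 2 by fluoro in place of methyl on an aromatic carbon, with fluoro in place of methyl on an aromatic carbon, meta to a large group.

Within the data shown here, with no measured step as a guide, no shift beyond the usual scatter is expected in this assay, and no direction is favoured. The assay may well report only a limit again for compound 4. The expected change is a number no higher from compound 2 to compound 4 (the limit leaves the size open). For compound 4 the estimated value is 50000 nM, with an expected range of 18000 nM to 120000 nM.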

Compound 4, half-maximal inhibitory concentration: > 50000 nM
Compound 4 ended at the assay's limit; the forecaster's own chance of this, stated with the estimate: 60%; the middle value lies on the limit itself.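

In this assay compound 2 and compound 4 both give a limit and not a number, so the change from methyl to fluoro on an aromatic carbon yields no step that can be read: the limit of > 50000 nM in this assay, at which 2 of the 4 values shown sit.

The compounds shown leave open where compound 2 and compound 4 stand on the scale, and what this single change does in this assay.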